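The compounds below may be only part of what the source reports. "The series", "measured", "known", "first", "only" and "open" are said of these compounds alone.

Working notes on the series

Compound 1 `N#Cc1cnc(NCc2cnccc2C(F)(F)F)cc1N[C@H]1C[C@@H](O)C1` is the starting point. In an assay on isolated protein for inhibition of protein kinase C delta type (Homo sapiens), read by TR-FRET, with a stated time of 2 h (a higher number here means a weaker inhibitor, a lower number a stronger inhibitor), compound 1 gives > 10000 nM, which is a limit of the assay and not a number, so its standing is known only as the weak end of the range covered here. Among the measured compounds shown here, the only other measured member, compound 2 `CC1(C)C[C@H](Nc2cc(NCc3cnccc3C(F)(F)F)ncc2C#N)CC(C)(C)[C@H]1O`, gives 500 nM in this assay.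

The step under consideration leads from compound 1 to compound 3 `CC1(C)C[C@@H](Nc2cc(NCc3cnccc3C(F)(F)F)ncc2C#N)CC[C@@H]1O`. The change is 4-hydroxy-3,3-dimethylcyclohexyl in place of 3-hydroxycyclobutyl on a nitrogen on an aromatic ring. For the measured compounds named here, no measured pair in the set differs in exactly this way, so no step size is directly available.

Compound 1 itself sits at the limit of > 10000 nM in this assay, at which 1 of the 2 values shown sits. Compound 3 is expected to be a stronger inhibitor than compound 1, with the step of an at least 6.6-fold lower number from compound 1 to compound 3 (0.82 log units; beyond the scatter) estimated to be of that size, because compound 2, which bears a larger ring at the same nitrogen, reaches 500 nM in this assay. The estimate for compound 3 in this assay is 1500 nM, with a range from 400 nM to 6000 nM.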

Compound 3, half-maximal inhibitory concentration: 2400 nM
Compound 3: the middle estimate sits 1.6-fold (0.20 log units) below what was measured; the measured number falls inside the stated range.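

In this assay compound 1 gives > 10000 nM, which is a limit of the assay and not a number. Among the compounds shown here, at the position on a nitrogen on an aromatic ring, 4-hydroxy-3,3-dimethylcyclohexyl in place of 3-hydroxycyclobutyl gives an at least 4.1-fold lower number from compound 1 to compound 3 (0.61 log units; beyond the scatter), the first step that can be read, and it shows that this position responds to a change of the ring while the core of compound 1 stays the same. The step is a lower bound and not a full size, because one end of it rests on a limit: the limit of > 10000 nM in this assay, at which 1 of the 3 values shown sits.

In this assay compound 2 gives 500 nM and compound 3 gives 2400 nM, but the compounds shown do not tell whether the difference from compound 1 follows the six-membered ring itself, the methyl groups on it, or the arrangement of its stereocentres. Also open, as far as these compounds go, is what a plain 4-hydroxycyclohexyl would give at this nitrogen, and whether the hydroxyl on the ring can be exchanged for an amine or a methoxy group.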